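This account rests on a few compounds, and the source may have more. Where it says the series, first, only, none or still open, it means among the compounds named here.

Measured so far:
compound 1, `CCCSc1nc(N/N=C/c2ccc(C)cc2)c2nnn(Cc3ccccc3)c2n1`: > 64000 nM
compound 2, `CCCSc1nc(N/N=C(\C)c2ccccc2O)c2nnn(Cc3ccccc3Cl)c2n1`: > 64000 nM

Of the compounds shown here, two have so far been tested in a functional assay on MCF7 cells (Homo sapiens) for antiproliferative activity, read by MTT assay, with a stated time of 72 h; a lower number here means a stronger inhibitor, a higher number a weaker inhibitor. Compound 1 `CCCSc1nc(N/N=C/c2ccc(C)cc2)c2nnn(Cc3ccccc3)c2n1` returns only a limit of the assay, > 64000 nM. Compound 2 `CCCSc1nc(N/N=C(\C)c2ccccc2O)c2nnn(Cc3ccccc3Cl)c2n1` likewise returns only a limit, > 64000 nM. Among the compounds with values here, compound 1 therefore stands at the top of the range this assay reports, and the only other measured compound sits there too; both values rest at the limit of > 64000 nM in this assay, at which 2 of the 2 values shown sit, so no step between the two can be sized, and neither can be called more or less potent than the other.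

The unmeasured compound 3 `CCCSc1nc(N/N=C(\C)c2ccccc2)c2nnn(Cc3ccccc3)c2n1` differs from compound 1 by a group of 9 heavy atoms (8 carbon, 1 nitrogen; one six-membered aromatic ring of carbon only) in place of a group of 9 heavy atoms (8 carbon, 1 nitrogen; one six-membered aromatic ring of carbon only), on a nitrogen on an aromatic ring. Within the data shown here, no measured pair shows what such a rearrangement does in this assay. With both measured values at the limit, compound 1 to compound 3 is expected to be a step of no size beyond the scatter, and compound 3 is expected most likely to return a limit again. Compound 3 is expected to give about 80000 nM in this assay, with a range from 30000 nM to 200000 nM. That estimate means an expected step that the limit leaves unreadable from compound 1 to compound 3.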

Compound 3, half-maximal inhibitory concentration: 32100 nM
Estimate against measurement, compound 3: 2.5-fold (0.40 log units) above, within the range that was stated.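

Compound 3 is the first compound shown to give a number rather than a limit in this assay, at 32100 nM. Compound 1 remains a limit, at > 64000 nM. Joining the same atoms differently in the group on a nitrogen on an aromatic ring gives an at least 1.9-fold lower number from compound 1 to compound 3 (0.29 log units; that floor lies within the scatter), so the rearrangement yields a readable value, but the floor of the step does not establish a change beyond the scatter, and the limit leaves its full size unknown.

Compound 2 differs from the others in more than one place, so it offers no clean comparison, and the compounds shown give few readable values: the limit of > 64000 nM in this assay, at which 2 of the 3 values shown sit. They leave open whether this modest reading can be pushed further, for instance by an amine or a carboxylic acid on the six-membered aromatic ring of this group, or by a longer chain in place of the propyl chain of the core of compound 3.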